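The compounds below may be only part of what the source reports. "The series", "measured", "known", "first", "only" and "open" are said of these compounds alone.

Measured so far:
- compound 1, `O=C(Nc1cccc(-c2ccoc2)c1)C(Cl)Cl`; in a functional assay on KB 3-1 cells (Homo sapiens) for cytotoxicity, read by MTT assay, with a stated time of 68 h (on this read-out lower numbers stand for stronger inhibition and higher numbers for weaker inhibition), compound 1 gives > 50000 nM, which is a limit of the assay rather than a number
- compound 2, `Cc1ccccc1-c1cccc(NC(=O)C(Cl)Cl)c1`; in this assay compound 2 gives 42000 nM
- compound 3, `CSc1ccccc1-c1cc(NC(=O)C(Cl)Cl)cc(-c2ccccc2SC)c1`; in this assay compound 3 gives > 30000 nM, again a limit of the assay and not a number

Compound 1 therefore stands at a limit: its value is the limit of > 50000 nM in this assay, at which 1 of the 3 values shown sits, so only an upper bound of its potency is known. Of the three values shown, two are limits and only compound 2 has a numerical result, and that result is weak.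

Compound 4, `O=C(Nc1cccc(-c2ccccc2)c1)C(Cl)Cl`, has not yet been measured. It differs from compound 1 by phenyl in place of furan-3-yl on an aromatic carbon. Within the data shown here, no measured pair in this set isolates that change, so the size of the step is open. Among the measured compounds shown here, the one compound that carries a phenyl group, compound 2, gives 42000 nM in this assay, and that result is weak. A step of an at least 1.1-fold lower number from compound 1 to compound 4 (0.04 log units; that floor lies within the scatter) is expected, at most a small one, and quite possibly none beyond the scatter.

Compound 4 is thus estimated at 45000 nM in this assay, within a range of 15000 nM to 150000 nM.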

Compound 4, half-maximal inhibitory concentration: 46800 nM
Compound 4: middle estimate off by 1.0-fold (0.02 log units), on the low side; the range from low to high includes it.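

Phenyl in place of furan-3-yl on this aromatic carbon gives an at least 1.0-fold lower number from compound 1 to compound 4 (0.02 log units; that floor lies within the scatter), so that floor shows no gain beyond the scatter, and the true size of the step remains unknown. In this assay compound 1 has only a limit and not a number: the limit of > 50000 nM in this assay, at which 1 of the 4 values shown sits. Hydrogen in place of methyl on the phenyl ring gives a 1.1-fold higher number from compound 2 to compound 4 (0.05 log units; within the scatter), which is the one step here between two numerical values and shows that this methyl makes no difference that can be told from the scatter.

From the compounds shown here alone, what remains open is whether any other kind of group at this position would give a clearly lower number. An amine or a carboxylic acid on the phenyl ring of compound 4 would put that question to the test.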